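The compounds below may be only part of what the source reports. "The series", "measured", "known", "first", "only" and "open" are said of these compounds alone.

Of the compounds shown here, two built on the shared core have been tested in a functional assay on HeLa cells (Homo sapiens) for cytotoxicity, read by CCK-8 assay, with a stated time of 24 h; on this read-out higher numbers stand for weaker inhibition and lower numbers for stronger inhibition. Compound 1 (`C/C(=C\c1cc(-c2ccc(C)nc2)co1)C(N)=O`) is one of them. In this assay compound 1 gives > 50000 nM, which is a limit of the assay rather than a number. Compound 2 (`C/C(=C\c1cc(-c2ccc(C)cc2)cs1)C(N)=O`) is the other. In this assay compound 2 gives > 50000 nM, again a limit and not a measured figure. Compound 2 therefore cannot be placed above or below its companion among the numbers shown, since both available results sit at the limit of > 50000 nM in this assay, at which 2 of the 2 values shown sit, and no order between the two can be read from them.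

Compound 3 (`C/C(=C\c1cc(-c2ccc(C#N)cc2)cs1)C(N)=O`) has not yet been measured. It differs from compound 2 in one place: cyano in place of methyl on an aromatic carbon. Within the data shown here, no step between measured compounds is available to guide the expectation, so the estimate rests on the two limits alone. The expected step is a number no higher from compound 2 to compound 3 (the limit leaves the size open), none beyond the usual scatter. For compound 3 in this assay the expected value is 50000 nM, with a range from 25000 nM to 100000 nM, and the most likely outcome is another limit rather than a number.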

Compound 3, half-maximal inhibitory concentration: 250 nM
The estimate for compound 3 lay 200-fold (2.30 log units) above the measured number; the whole stated range lies above it.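

Cyano in place of methyl on an aromatic carbon of the six-membered aromatic ring of carbon only, para to a large group, brings an at least 200-fold lower number from compound 2 to compound 3 (2.30 log units; beyond the scatter) in this assay, so a single change at this position is enough to separate a limit from a measured number. The earlier compounds shown here, both sitting at the limit, gave no sign that anything on the shared core could reach a number on this read-out; compound 3 shows that it can, at least for this one pair. The true size of the step remains unknown because compound 2 offers only a limit and not a number: the limit of > 50000 nM in this assay, at which 2 of the 3 values shown sit.

What the compounds shown leave open is whether cyano is special at this carbon, or whether a carboxylic acid, an amine or a methoxy group in the same place would also give a number rather than a limit. They also leave open whether the same change would carry over to the core of compound 1, and they give no reason why this change acts as it does.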